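A few compounds are considered here, and "the series" means these few. Any claim that something is new, unique, unknown or untested is made for them only; others in the source may bear on it.

Working notes on the series. In a functional assay on HCT-15 cells (Homo sapiens) for cytotoxicity, read by ELISA, with a stated time of 2 days (a lower number here means a stronger inhibitor, a higher number a weaker inhibitor), compound 1 `Oc1cccc(-c2cc(-c3ccccc3)cc(-c3ccccc3)n2)c1` gives 9950 nM; compound 2 `Oc1cccc(-c2cc(-c3ccccc3)cc(-c3cccs3)n2)c1` gives 10900 nM and compound 3 `Oc1cccc(-c2cc(-c3ccccc3)cc(-c3ccco3)n2)c1` gives 13500 nM, so the three numbers sit together, with compound 1 not separated from either neighbour beyond the scatter. The steps of a 1.1-fold higher number from compound 1 to compound 2 (0.04 log units; within the scatter), a 1.4-fold higher number from compound 1 to compound 3 (0.13 log units; within the scatter) and a 1.2-fold higher number from compound 2 to compound 3 (0.09 log units; within the scatter) all stay within the scatter. Compound 4 `Oc1cccc(-c2cc(-c3ccccc3)cc(-c3cccc(O)c3)n2)c1` differs from compound 1 by hydroxy in place of hydrogen on an aromatic carbon. Among the measured compounds shown here, no measured step bears on such a change: the three measured steps exchange the whole aryl group, and none adds a hydroxy. With that, and the flat run across the three measured compounds, no step beyond the scatter is expected, and compound 4 is estimated at 8500 nM, range 3000 nM to 25000 nM, a step of a 1.2-fold lower number from compound 1 to compound 4 (0.07 log units; within the scatter).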

Compound 4, half-maximal inhibitory concentration: 18400 nM
Beside the measured number, compound 4's estimate is 2.2-fold (0.34 log units) below it; the range from low to high includes it.
By their numbers in this assay, from the lowest: compounds 1, 2, 3 and 4 (each within the scatter of the next).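

Phenyl to 3-hydroxyphenyl is the first change in the series that adds a group to an aryl ring instead of exchanging the whole ring, and in this assay it gives a 1.8-fold higher number from compound 1 to compound 4 (0.27 log units; within the scatter). The exchanges of the other aryl groups for 3-hydroxyphenyl give a 1.7-fold higher number from compound 2 to compound 4 (0.23 log units; within the scatter) and a 1.4-fold higher number from compound 3 to compound 4 (0.13 log units; within the scatter). Hydroxy at this position therefore leaves every step within the scatter, as the whole-ring exchanges did.

On these data alone, whether a methoxy, an amine or a carboxylic acid in place of this hydroxy would give a step beyond the scatter stays open. No measurement shown here explains these numbers.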